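The source may hold more compounds than are shown below. What is called first, only, known or untested is meant among the compounds shown, and "the series" means these compounds.

Measured compounds, with their values in a functional assay on HepG2 cells (Homo sapiens) for cytotoxicity, with a stated time of 72 h; a lower number here means that less compound is needed, a higher number that more compound is needed for the effect:

Compound 1 `C=C[C@@](C)(/C=C/c1ccc(O)c(/C=C/c2ccc(F)cc2)c1)CCC=C(C)C`: in this assay compound 1 gives > 52000 nM, which is a limit of the assay and not a number.
Compound 2 `C=C[C@@](C)(/C=C/c1ccc(O)c(/C=C/c2ccc(Cl)cc2)c1)CCC=C(C)C`: in this assay compound 2 gives > 52000 nM, likewise a limit of the assay.
Compound 3 `CC(C)=CCC[C@](C)(/C=C/c1ccc(O)cc1)/C=C/c1cccc(F)c1`: in this assay compound 3 gives > 52000 nM, again a limit of the assay.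

The step from compound 1 to compound 2 is chloro in place of fluoro on an aromatic carbon. It reads a step that the two limits leave unreadable from compound 1 to compound 2, because of the limit of > 52000 nM in this assay, at which 3 of the 3 values shown sit.

Compound 4 `CC(C)=CCC[C@](C)(/C=C/c1ccc(O)cc1)/C=C/c1cccc(Cl)c1` is not yet measured. It differs from compound 3 by chloro in place of fluoro on an aromatic carbon. The place differs from the earlier case: para to a large group there, meta to a large group here, so the two changes are the same kind of change, not the same. The difference between the two cores of compound 1 and compound 3 is not broken down here.

For compound 4 in this assay a step that the limit leaves unreadable from compound 3 to compound 4 is expected, resting on compound 3 sitting at > 52000 nM. Compound 4 is estimated at 90000 nM, with the range 30000 nM to 400000 nM.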

Compound 4, half-maximal effective concentration: > 52000 nM
Compound 4: no number, only a limit; the forecaster's own chance of this, stated with the estimate: 90%; the middle value does not contradict the limit.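

In this assay compound 4 gives > 52000 nM, a limit of the assay and not a number. No step can be read between compound 3 and compound 4, because the values stop at the same limit: the limit of > 52000 nM in this assay, at which 4 of the 4 values shown sit.

The compounds shown leave open how chloro and fluoro compare on either core, and at what concentration any of the four compounds would reach the effect.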